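This account rests on a few compounds, and the source may have more. Where it says the series, first, only, none or still open, it means among the compounds named here.

Three purine-type compounds have numbers in a functional assay on HCC 2998 cells (Homo sapiens) for cytotoxicity, read by sulforhodamine B assay, with a stated time of 48 h; on this read-out lower numbers stand for stronger inhibition of growth and higher numbers for weaker inhibition of growth. Compound 1 `ClCc1ccc(Cn2cnc3c(Cl)ncnc32)cc1` gives 660 nM. Compound 2 `ClCc1ccc(Cn2cnc3nc(Cl)nc(Cl)c32)cc1` gives 2040 nM, which stands second highest of the three numbers; compound 3 `ClCc1ccccc1Cn1cnc2ncnc(Cl)c21` gives 2230 nM, within the usual scatter of compound 2, while compound 1 sits furthest away, beyond the scatter. Compound 4 `ClCc1ccc(Cn2cnc3ncnc(Cl)c32)cc1` has not been measured in this assay. It differs from compound 2 in one place: hydrogen in place of chloro on an aromatic carbon. Within the data shown here, no measured pair shows this exact change, so the step is expected to be small, in either direction or none beyond the scatter. The expected number for compound 4 is 1500 nM, with a range from 500 nM to 5000 nM, an expected step of a 1.4-fold lower number from compound 2 to compound 4 (0.13 log units; within the scatter).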

Compound 4, concentration for 50% growth inhibition: 1410 nM
For compound 4 the middle estimate is 1.1-fold (0.03 log units) above the measured one, and the stated range covers the measured number.
By their numbers in this assay, from the lowest: compound 1; then compounds 4, 2 and 3 (each within the scatter of the next).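

Hydrogen in place of chloro on an aromatic carbon, between two ring nitrogen atoms, is the first change in a single place here, and in this assay it gives a 1.4-fold lower number from compound 2 to compound 4 (0.16 log units; within the scatter). At this position, then, compound 2 and compound 4 cannot be told apart, so the chloro group is not needed to keep the growth inhibition seen here. Nothing measured on these compounds offers an explanation for this result. From the compounds shown here alone, whether an amine or a methoxy group on this carbon would give a step beyond the scatter stays open.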